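Notes on the series: compound 3 to compound 4

The source may report more compounds than this note shows. Statements on the series, on what has been measured and on what is new or still open speak of the compounds shown alone.

Measured in a functional assay on A2780 cells (Homo sapiens) for cytotoxicity, read by sulforhodamine B assay, with a stated time of 72 h; on this read-out higher numbers stand for weaker inhibition and lower numbers for stronger inhibition 
- compound 1 `O=C(NCc1ccc(S(=O)(=O)c2cccc(C(F)(F)F)c2)cc1)N1Cc2ccncc2C1` gives 2.7 nM 
- compound 2 `O=C(NCc1ccc(S(=O)(=O)c2cc(F)cc(F)c2)cc1)N1Cc2ccncc2C1` gives 6.3 nM 
- compound 3 `O=C(NCc1ccc(S(=O)(=O)C2CCCOC2)cc1)N1Cc2ccncc2C1` gives 32 nM 

Compound 3 has the highest number of the three, and so the weakest inhibition. Compound 4 `CC(=O)N1CCC(S(=O)(=O)c2ccc(CNC(=O)N3Cc4ccncc4C3)cc2)CC1` has 1-acetylpiperidin-4-yl in place of oxan-3-yl on a sulfonyl sulfur. Among the compounds with values here, three measured steps concern this place: a 2.3-fold higher number from compound 1 to compound 2 (0.37 log units; beyond the scatter), a 5.1-fold higher number from compound 2 to compound 3 (0.71 log units; beyond the scatter) and a 12-fold higher number from compound 1 to compound 3 (1.07 log units; beyond the scatter). Within the data shown here, the two large-to-modest steps into oxan-3-yl both start from a substituted phenyl, and no measured step joins two non-aromatic rings, so they set no clear direction here. In this assay the expected step is a 1.5-fold lower number from compound 3 to compound 4 (0.16 log units; within the scatter), with no change beyond the scatter expected. Compound 4 is estimated at 22 nM, with an expected range of 7 nM to 70 nM.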

Compound 4, half-maximal inhibitory concentration: 110 nM
Compound 4: middle estimate off by 5.0-fold (0.70 log units), on the low side; measured number above the stated range.
By their numbers in this assay, from the lowest: compound 1; then compound 2; then compound 3; then compound 4.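

In this assay, the sulfonyl position still responds to a change between two non-aromatic rings, with a 3.4-fold higher number from compound 3 to compound 4 (0.54 log units; beyond the scatter). The distance from the aromatic groups also grows, with a 17-fold higher number from compound 2 to compound 4 (1.24 log units; beyond the scatter) and a 41-fold higher number from compound 1 to compound 4 (1.61 log units; beyond the scatter), which leaves compound 4 with the weakest inhibition of the four. Nothing available bears on the cause of these steps.

The compounds shown leave open whether this step follows the acetyl group, the ring nitrogen or the ring's point of attachment. A comparison with oxan-4-yl or with piperidin-4-yl lacking the acetyl would help separate these.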